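This account rests on a few compounds, and the source may have more. Where it says the series, first, only, none or still open, it means among the compounds named here.

Compound 1 `Sc1ncnc2c(Cc3ccccc3)ncn12` and compound 2 `Cc1ccc(Cc2ncn3c(S)ncnc23)cc1` share one core and differ only by methyl in place of hydrogen on an aromatic carbon. In a functional assay on CCRF-CEM cells (Homo sapiens) for cytotoxicity (on this read-out higher numbers stand for lower toxicity in this test and lower numbers for higher toxicity in this test), compound 1 gives 35100 nM, and compound 2 gives 32800 nM; the step is a 1.1-fold lower number from compound 1 to compound 2 (0.03 log units; within the scatter). Compound 3 `Cc1ncn2c(S)ncnc12` is a smaller compound; the difference between its core and the core of compound 1 is not broken down here. In this assay compound 3 gives 789000 nM, the highest number of the three, and its gap to compound 1 as well as to compound 2 lies beyond the scatter.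

Compound 4 `Cc1nc(C)n2c(S)ncnc12` has not been measured and differs from compound 3 by methyl in place of hydrogen on an aromatic carbon. This is the same kind of change as from compound 1 to compound 2, not the same: there the methyl entered on a six-membered aromatic ring of carbon only, para to a large group, whereas here it enters on a five-membered aromatic ring with 2 nitrogen, part of a fused or bridged system of two rings, between two ring nitrogen atoms, two ring bonds from the ring atom that bears a methyl group. Within the data shown here, only one measured instance of this kind of change exists, and it sits at a different place; the expectation rests on that alone. In this assay the expected step is a 1.2-fold lower number from compound 3 to compound 4 (0.08 log units; within the scatter), set beside the earlier one because the measured precedent was a 1.1-fold lower number from compound 1 to compound 2 (0.03 log units; within the scatter). The estimate for compound 4 is 650000 nM, with an expected range from 250000 nM to 1600000 nM.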

Compound 4, half-maximal cytotoxic concentration: > 694000 nM
Compound 4 was reported as a limit; the forecaster's own chance of this, stated with the estimate: 20%; middle value at least 1.0-fold (0.02 log units) away from the limit.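

In this assay compound 4 gives > 694000 nM as a limit of the assay, not a number. The step from compound 3 to compound 4 therefore cannot be read: the limit of > 694000 nM in this assay, at which 1 of the 4 values shown sits.

The compounds shown leave open whether methyl in place of hydrogen on this aromatic carbon of the five-membered aromatic ring changes the read-out at all, and in which direction.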